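Trading a 4-aminophenyl for a 3,4-difluorophenyl in compound 1

A few compounds are considered here, and "the series" means these few. Any claim that something is new, unique, unknown or untested is made for them only; others in the source may bear on it.

The three measured compounds and their results in a functional assay on COLO 205 cells (Homo sapiens) for cytotoxicity, read by sulforhodamine B assay, with a stated time of 48 h, tested at 10 uM (a lower number here means a stronger effect, a higher number a weaker effect of the compound at the concentration tested), are:

Compound 1 `COc1cc(-c2cc(/C=C/C(=O)c3ccc(N)cc3)[nH]n2)cc(OC)c1OC`: -84%
Compound 2 `COc1ccc(-c2cc(/C=C/C(=O)c3ccc(OC)c(OC)c3)[nH]n2)cc1`: -89%
Compound 3 `COc1ccc(-c2cc(/C=C/C(=O)c3ccc(N)cc3)[nH]n2)cc1OC`: -79%

Compound 1 stands second highest of the three numbers. Its nearest neighbour is compound 2, and the two values lie within the scatter of each other, so no order between them can be read. Among the measured compounds shown here, the one single-point step that is known runs a number 5 percentage points higher from compound 1 to compound 3 (within the scatter), again inside the scatter.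

Compound 4 `COc1cc(-c2cc(/C=C/C(=O)c3ccc(F)c(F)c3)[nH]n2)cc(OC)c1OC` differs from compound 1 in one place: 3,4-difluorophenyl in place of 4-aminophenyl on a carbonyl carbon. For the measured compounds named here, no measured step bears directly on this change. The step of a number 5 percentage points higher from compound 1 to compound 3 (within the scatter) touches a different part of the molecule, and compound 2, which carries a different ring on the carbonyl carbon, also differs from compound 1 elsewhere, so its value is not a clean comparison. What the three numbers do show is that all three compounds sit close together in this assay. On that basis the step of a number 4 percentage points higher from compound 1 to compound 4 (within the scatter) is expected to stay within the scatter, in no clear direction. Compound 4 is therefore estimated at -80%, with a range from -95% to -60%.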

Compound 4, a percentage reported as activity, at one concentration (the size of the read-out at that concentration, not a potency): -90%
Compound 4: the middle estimate sits 10 percentage points above what was measured; low and high end bracket the measured number.
By their numbers in this assay, from the lowest: compounds 4, 2, 1 and 3 (each within the scatter of the next, the first and the last beyond it).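

In this assay, among the compounds shown here, the first clean comparison at this position puts 3,4-difluorophenyl in place of 4-aminophenyl on the carbonyl carbon and gives a number 6 percentage points lower from compound 1 to compound 4 (within the scatter). On the core of compound 1, then, this position accepts a ring with a different substitution and no measurable change in the read-out, even though the 4-aminophenyl counts a hydrogen-bond donor and a hydrogen-bond acceptor and the 3,4-difluorophenyl counts neither. Nothing measured here bears on why the two groups behave alike in this pair.

This single pair cannot show how much freedom the position really allows, and an unsubstituted phenyl, a 4-hydroxyphenyl, a ring carrying a carboxylic acid or a saturated cyclohexyl could each test it further. The read-out also comes from one concentration, so compound 1 and compound 4 could still differ in the size of their effect at lower concentrations, and testing at further concentrations would be needed to separate them.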